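Swapping Ethyl for Cyclopropyl on a Saturated Ring Carbon

This account rests on a few compounds, and the source may have more. Where it says the series, first, only, none or still open, it means among the compounds named here.

Of the compounds shown here, three have been tested in a functional assay on KB cells (Homo sapiens), read by MTT assay; on this read-out lower numbers stand for stronger inhibition and higher numbers for weaker inhibition. Compound 1 `C#C[C@@H]1[C@@H](O)[C@H](n2ccc(=O)[nH]c2=O)O[C@@H]1CO` gives only a limit there, > 350000 nM, not a number. Compound 2 `C#CC[C@]1(O)[C@@H](CO)OC(n2ccc(N)nc2=O)[C@@H]1O` likewise gives only a limit, > 350000 nM. Going by the values given here, compound 3 `CC[C@@]1(O)[C@@H](CO)O[C@@H](n2ccc(N)nc2=O)[C@@H]1O` is the one member of the set with a measured number, 258000 nM, a weak inhibition. Two of the three values sit at the limit (the limit of > 350000 nM in this assay, at which 2 of the 3 values shown sit), so compound 3 is the only point from which a step can be judged.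

Compound 4 `Nc1ccn([C@@H]2O[C@H](CO)[C@](O)(C3CC3)[C@H]2O)c(=O)n1` has not yet been tested in this assay. It differs from compound 3 in one place: cyclopropyl in place of ethyl on a saturated ring carbon. Among the compounds with values here, no measured pair here shows what such an exchange does, so the expected step of a 1.0-fold lower number from compound 3 to compound 4 (0.01 log units; within the scatter) is set at none beyond the usual scatter. Compound 4 is therefore expected to give about 250000 nM in this assay, within a range from 60000 nM to 350000 nM.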

Compound 4, half-maximal inhibitory concentration: > 350000 nM
Compound 4 gave a limit, no number; the forecaster's own chance of this, stated with the estimate: 45%; at least 1.4-fold (0.14 log units) between middle value and limit.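

Going by these compounds alone, the first exchange at this saturated ring carbon that can be read in this assay, cyclopropyl in place of ethyl, gives an at least 1.3-fold higher number from compound 3 to compound 4 (0.13 log units; that floor lies within the scatter). Compound 4 gives a limit and not a number, so only the lowest possible size of this step is known, and the real step could be larger. The change therefore offers no sign of stronger inhibition than ethyl, and the comparison ends at the edge of what the assay reports: the limit of > 350000 nM in this assay, at which 3 of the 4 values shown sit.

The compounds shown leave open how far the number for compound 4 lies from that for compound 3. They also leave open whether a methyl group or an amine on this ring carbon would give a lower number than ethyl.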